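From tert-butoxycarbonyl to methyl on an amine nitrogen

The compounds below may be only part of what the source reports. "The series", "measured", "known", "first", "only" and "open" are said of these compounds alone.

In a functional assay for inhibition, with Rattus norvegicus as the target (a higher number here means that more compound is needed for the effect, a lower number that less compound is needed), three compounds have been measured
compound 1 `CCCC[C@H](CC1CCCCC1)NCc1ccc(C(=O)N[C@@H](CCSC)C(=O)O)c(-c2ccccc2C)c1` gives 4.3 nM
compound 2 `CSCC[C@H](NC(=O)c1ccc(CN[C@H](CCCC(C)C)CC2CCCCC2)cc1-c1ccccc1C)C(=O)O` gives 52 nM
compound 3 `CSCC[C@H](NC(=O)c1ccc(CN(CCC2CCCCC2)C(=O)OC(C)(C)C)cc1-c1ccccc1C)C(=O)O` gives 160 nM

Compound 3 has the highest number of the three. Compound 4 `CSCC[C@H](NC(=O)c1ccc(CN(C)CCC2CCCCC2)cc1-c1ccccc1C)C(=O)O`, not yet measured, has methyl in place of tert-butoxycarbonyl on an amine nitrogen. Among the compounds with values here, no measured step touches this group. Within the data shown here, the only measured step, a 12-fold higher number from compound 1 to compound 2 (1.08 log units; beyond the scatter), lies on a saturated chain carbon, so it bears only indirectly and shows that one change can give a large step in this assay. Compounds 1 and 2 lack tert-butoxycarbonyl and both have lower numbers than compound 3, but they differ in more than that group. A moderate step to a lower number is therefore expected, with wide uncertainty. The estimated step is a 2.0-fold lower number from compound 3 to compound 4 (0.30 log units; within the scatter). The expected value for compound 4 is 80 nM, with an estimated range of 15 nM to 400 nM.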

Compound 4, half-maximal effective concentration: 12 nM
Beside the measured number, compound 4's estimate is 6.7-fold (0.82 log units) above it; the measured number lies below the stated range.
By their numbers in this assay, from the lowest: compound 1; then compound 4; then compound 2; then compound 3.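

In this assay, within the data shown here, methyl in place of tert-butoxycarbonyl on an amine nitrogen gives a 13-fold lower number from compound 3 to compound 4 (1.12 log units; beyond the scatter) and so shows for the first time that a change of group on this nitrogen can by itself produce a large step. The substituent here therefore matters in this series, and the smaller group gives the lower number in this one pair. No available evidence bears on the reason for this step. From the compounds shown here alone, whether an acetyl or an ethyl group would follow methyl or tert-butoxycarbonyl remains open, so this single pair does not separate the carbonyl from the size of the group.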